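Swapping the ring on the amide carbonyl of a chalcone series

The source may report more compounds than this note shows. Statements on the series, on what has been measured and on what is new or still open speak of the compounds shown alone.

Measured compounds:
- compound 1, `COc1cc(/C=C/C(=O)c2cccc(NC(=O)c3cccs3)c2)ccc1O`: 3.98 ug/mL
- compound 2, `COc1cc(/C=C/C(=O)c2cccc(NC(=O)c3ccco3)c2)ccc1O`: 3.11 ug/mL
- compound 3, `COC(=O)C(=O)Nc1cccc(C(=O)/C=C/c2ccc(O)c(OC)c2)c1`: 3.55 ug/mL

All three share the same core and differ only in the group attached to the carbonyl carbon of the amide. In a functional assay on Vero cells (Chlorocebus sabaeus) for inhibition (on this read-out higher numbers stand for weaker inhibition and lower numbers for stronger inhibition), compound 1 gives the highest number of the three, but its steps to the others are small: a 1.3-fold lower number from compound 1 to compound 2 (0.11 log units; within the scatter) and a 1.1-fold lower number from compound 1 to compound 3 (0.05 log units; within the scatter) both fall within the scatter, as does a 1.1-fold higher number from compound 2 to compound 3 (0.06 log units; within the scatter). Within the data shown here, on these numbers, no compound can be called the stronger or weaker inhibitor.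

Compound 4, `COc1cc(/C=C/C(=O)c2cccc(NC(=O)c3ccccc3)c2)ccc1O`, has not yet been measured. It differs from compound 1 by phenyl in place of thiophen-2-yl on a carbonyl carbon. The measured steps that bear on this change are those at the same carbonyl carbon, from compound 1 to compound 2 and from compound 1 to compound 3, and neither moved beyond the scatter. On that basis the expected step in this assay is none beyond the scatter, in either direction. For compound 4 the estimate is 3.6 ug/mL, with a range from 1.8 ug/mL to 7.2 ug/mL, which means an expected step of a 1.1-fold lower number from compound 1 to compound 4 (0.04 log units; within the scatter).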

Compound 4, half-maximal inhibitory concentration: 3.47 ug/mL
Compound 4: the middle estimate sits 1.0-fold (0.02 log units) above what was measured; measured number inside the range.
By their numbers in this assay, from the lowest: compounds 2, 4, 3 and 1 (each within the scatter of the next).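

Phenyl on this carbonyl carbon, a six-membered aromatic ring of carbon only, is the first group here that is not a five-membered ring or methoxycarbonyl, and in this assay it changes nothing that can be read: there is a 1.1-fold lower number from compound 1 to compound 4 (0.06 log units; within the scatter) and a 1.0-fold lower number from compound 3 to compound 4 (0.01 log units; within the scatter) and also a 1.1-fold higher number from compound 2 to compound 4 (0.05 log units; within the scatter) as the steps to the three earlier compounds. Across these four compounds, then, neither the larger ring nor the loss of the ring hetero atom moves the number beyond the scatter.

Open is whether an amine, a carboxylic acid or a longer alkyl chain on the same carbonyl carbon would also stay within the scatter, since all four groups shown carry no net charge. No measurement shown explains why this position tolerates these swaps.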